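A Fluorinated Anilino Analogue Expected from a Chlorinated One

This account rests on a few compounds, and the source may have more. Where it says the series, first, only, none or still open, it means among the compounds named here.

Compound 1 `O=C1C(N2CCCCC2)=CC(=O)c2c1nc1n2[C@H]2OC[C@@H](O)[C@H]2OC1` reaches only the limit of a functional assay on ECa-109 cells for inhibition, with ECa-109 cell line (Homo sapiens) as the target, read by sulforhodamine B assay (on this read-out lower numbers stand for stronger inhibition and higher numbers for weaker inhibition), reported as > 8000 nM. Within the data shown here, compound 2 `O=C1C=C(Nc2cccc(Cl)c2)C(=O)c2c1nc1n2[C@H]2OC[C@@H](O)[C@H]2OC1` provides the single real number in this set: in this assay compound 2 shows 4690 nM. Compound 3 `O=C1C=C(Nc2ccccc2F)C(=O)c2c1nc1n2[C@H]2OC[C@@H](O)[C@H]2OC1` carries 2-fluorophenyl in place of 3-chlorophenyl on an amine nitrogen. Among the measured compounds shown here, no measured pair tells how such a change plays out here, so the step of a 1.2-fold higher number from compound 2 to compound 3 (0.07 log units; within the scatter) is expected to stay within the usual scatter, in either direction. Compound 3 is therefore estimated at 5500 nM, with a range from 2000 nM to 15000 nM, and a fair chance that only a limit is returned.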

Compound 3, half-maximal inhibitory concentration: 2760 nM
For compound 3 the middle estimate is 2.0-fold (0.30 log units) above the measured one, and the stated range covers the measured number.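

Among these compounds, replacing 3-chlorophenyl with 2-fluorophenyl on the amine nitrogen gives a 1.7-fold lower number from compound 2 to compound 3 (0.23 log units; within the scatter) in this assay and is the first step that can be read at this position. The two aryl groups therefore cannot be told apart on this read-out, even though both the halogen and its ring position change. Nothing given here bears on a cause for this step.

The compounds shown do not separate the change of halogen from the change of its ring position. On these data alone, how an unsubstituted phenyl, a methoxy group or a carboxylic acid on this ring would read remains open.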